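The source may hold more compounds than are shown below. What is called first, only, known or untested is meant among the compounds shown, and "the series" means these compounds.

Working notes on the series. In a functional assay on NCI-H1993 cells (Homo sapiens) for inhibition, read by CCK-8 assay, with a stated time of 72 h (on this read-out higher numbers stand for weaker inhibition and lower numbers for stronger inhibition), compound 2 (`CN(C)c1cccc(-c2cnc3ncn(Cc4ccc5ncccc5c4)c3n2)c1`) gives > 10000 nM, which is a limit of the assay and not a number. Compound 1 (`Oc1nc2ncc(-c3ccncc3)nc2n1Cc1ccc2ncccc2c1`) gives > 10000 nM, also a limit. Among the measured compounds shown here, all that can be said of compound 2 is therefore (the limit of > 10000 nM in this assay, at which 2 of the 2 values shown sit), and no measured step is available to size a change. Compound 3 (`c1cnc2ccc(Cn3cnc4ncc(-c5ccncc5)nc43)cc2c1`) carries pyridin-4-yl in place of 3-(dimethylamino)phenyl on an aromatic carbon. Pyridin-4-yl is also present on compound 1, which remains at the limit of > 10000 nM in this assay, so no gain beyond the scatter is expected from this swap. The expected change is a number no higher from compound 2 to compound 3 (the limit leaves the size open) in this assay, a result close to the limit. For compound 3 the estimated value is 10000 nM, with an expected range from 2500 nM to 30000 nM.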

Compound 3, half-maximal inhibitory concentration: 1160 nM
Beside the measured number, compound 3's estimate is 8.6-fold (0.94 log units) above it; the measured number lies below the stated range.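

In this assay, among the compounds shown here, compound 3 gives the only value of the series that is not a limit, so this aromatic carbon of the shared core can carry a group compatible with measurable inhibition. Pyridin-4-yl in place of 3-(dimethylamino)phenyl gives an at least 8.6-fold lower number from compound 2 to compound 3 (0.93 log units; beyond the scatter), yet pyridin-4-yl alone does not suffice, as hydrogen in place of hydroxy gives an at least 8.6-fold lower number from compound 1 to compound 3 (0.93 log units; beyond the scatter). The true size of both steps stays open, as each starts from a limit: the limit of > 10000 nM in this assay, at which 2 of the 3 values shown sit.

On these data alone, whether an unsubstituted phenyl or a morpholine at the pyridin-4-yl position would keep this level of inhibition remains open. Also open, as far as these compounds go, is whether a methyl or an amine in place of the hydrogen that replaces hydroxy would be tolerated.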